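Chloro for Fluoro on the Phenyl of Compound 3

The compounds below may be only part of what the source reports. "The series", "measured", "known", "first", "only" and "open" are said of these compounds alone.

Of the compounds shown here, three sharing one core have been measured in an in vitro ADME assay on microsomes from liver (Homo sapiens) for metabolic stability; on this read-out lower numbers stand for slow clearance and higher numbers for fast clearance. Compound 1 `O=C(Nc1c(Cl)cc(F)cc1Cl)N1CCN2C(=O)N([C@H]3C[C@@H]3c3ccccc3)C(=O)[C@@H]2C1` gives 64000 mL.min-1.g-1 in this assay. Compound 2 `N#Cc1cc(Cl)c(NC(=O)N2CCN3C(=O)N([C@H]4C[C@@H]4c4ccccc4)C(=O)[C@@H]3C2)c(Cl)c1` gives 66000 mL.min-1.g-1, and the step of a 1.0-fold higher number from compound 1 to compound 2 (0.01 log units; within the scatter) stays within the scatter. Compound 3 `O=C(Nc1ccnn1-c1cccc(F)c1)N1CCN2C(=O)N([C@H]3C[C@@H]3c3ccccc3)C(=O)[C@@H]2C1` gives 45000 mL.min-1.g-1, a number that lies within the scatter of both compound 1 and compound 2, so the three measured compounds are not separated from one another in this assay.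

Compound 4 `O=C(Nc1ccnn1-c1cccc(Cl)c1)N1CCN2C(=O)N([C@H]3C[C@@H]3c3ccccc3)C(=O)[C@@H]2C1` has not yet been measured. It differs from compound 3 by chloro in place of fluoro on an aromatic carbon. Going by the values given here, no measured step alters a halogen on this ring; the only step available, a 1.0-fold higher number from compound 1 to compound 2 (0.01 log units; within the scatter), exchanges a group on a different aromatic ring and remains within the scatter. There is thus no measured evidence that a single-atom exchange of this kind moves the number beyond the scatter, and all three measured values sit close together. Compound 4 is therefore expected to land near compound 3, with the estimated step of a 1.1-fold higher number from compound 3 to compound 4 (0.05 log units; within the scatter) lying within the scatter in either direction. The estimate for compound 4 in this assay is 50000 mL.min-1.g-1, with an expected range from 25000 mL.min-1.g-1 to 100000 mL.min-1.g-1.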

Compound 4, intrinsic clearance in microsomes: 62000 mL.min-1.g-1
Estimate against measurement, compound 4: 1.2-fold (0.09 log units) below, within the range that was stated.
By their numbers in this assay, from the lowest: compounds 3, 4, 1 and 2 (each within the scatter of the next).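

In this assay, going by these compounds alone, going from 3-fluorophenyl to 3-chlorophenyl gives a 1.4-fold higher number from compound 3 to compound 4 (0.14 log units; within the scatter), and this is the first measured step that alters a halogen on this ring. At this place, on an aromatic carbon meta to a large group, the read-out therefore does not separate chloro from fluoro, so an exchange of one halogen for another on this ring leaves compound 3 and compound 4 within the scatter of each other. The earlier step, a 1.0-fold higher number from compound 1 to compound 2 (0.01 log units; within the scatter), concerned cyano and fluoro on a different aromatic ring, and with the new step there are now two single-place exchanges on aromatic carbons, neither of which goes beyond the scatter, though no information available here bears on the reason for this result.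

From the compounds shown here alone, both groups compared at this place are single halogen atoms, so it remains open whether a larger or different group there, such as a methoxy group, an amine or a carboxylic acid, would move the number beyond the scatter. Going by these compounds, it is also open whether the exchange of chloro for fluoro would read the same on another carbon of this ring, or on a different core.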